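Halogen swap on a nitrophenyl arm of a sulfonyl enone

The source may report more compounds than this note shows. Statements on the series, on what has been measured and on what is new or still open speak of the compounds shown alone.

Compound 1 `O=C(/C(=C\c1ccc(F)c([N+](=O)[O-])c1)S(=O)(=O)c1ccc(Br)cc1)c1ccc(Br)cc1`: 25000 nM
Compound 2 `Cc1ccc(S/C(=C/c2ccc[nH]2)C(=O)c2ccc(Cl)cc2)cc1`: 10000 nM
Compound 3 `Cc1ccc(S(=O)(=O)/C(=C/c2c[nH]c3ccc(Cl)cc23)C(=O)c2ccc(Br)cc2)cc1`: 10000 nM

In a functional assay on DU-145 cells (Homo sapiens) for inhibition, read by trypan blue exclusion, with a stated time of 96 h (on this read-out lower numbers stand for stronger inhibition of growth and higher numbers for weaker inhibition of growth), compound 1 gives 25000 nM, the highest of the three numbers; compound 2 and compound 3 each sit at a lower number, and both gaps lie beyond the scatter. Compound 4 `O=C(/C(=C\c1ccc(Br)c([N+](=O)[O-])c1)S(=O)(=O)c1ccc(Br)cc1)c1ccc(Br)cc1` has not yet been measured. It differs from compound 1 in one place: bromo in place of fluoro on an aromatic carbon. Among the measured compounds shown here, no measured pair shows the effect of this change, so only a small step is expected, with no direction beyond the scatter, and the step from compound 1 to compound 4 is estimated at a 1.3-fold lower number from compound 1 to compound 4 (0.10 log units; within the scatter). Compound 4 is therefore expected to give about 20000 nM, between 8000 nM and 50000 nM.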

Compound 4, concentration for 50% growth inhibition: 10000 nM
Beside the measured number, compound 4's estimate is 2.0-fold (0.30 log units) above it; measured number inside the range.
By their numbers in this assay, from the lowest: compounds 2, 3 and 4 (each within the scatter of the next); then compound 1.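

In this assay, among the compounds shown here, bromo in place of fluoro gives a 2.5-fold lower number from compound 1 to compound 4 (0.40 log units; beyond the scatter) and this is the first measured pair in the set. It shows that this aromatic carbon, ortho to a nitro group, responds to the exchange of one halogen for another, with a modest step beyond the scatter. Nothing available explains the step.

With only fluoro and bromo compared, the compounds shown leave open how chloro, an amine or a methoxy group would read at this carbon, and whether the step holds without the nitro group.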